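The source may report more compounds than this note shows. Statements on the series, on what has been measured and on what is new or still open speak of the compounds shown alone.

Measured so far:
compound 1, `COC(=O)C1=C(C)N=C(C)/C(=C(/O)OC)C1c1c(F)cccc1Cl`: 7.59 nM
compound 2, `C=Cc1ccccc1C1C(C(=O)OC)=C(C)N=C(C)/C1=C(\O)OC`: 4.47 nM
compound 3, `COC(=O)C1=C(C)N=C(C)/C(=C(\O)OC)C1c1cccc(OC(=O)c2ccccc2)c1`: 6310 nM

In a functional assay (muscle tissue) with Cavia porcellus as the target (a lower number here means that less compound is needed, a higher number that more compound is needed for the effect), compound 2 gives the lowest of the three numbers. Compound 1 sits within the scatter of it, so the two cannot be ordered; compound 3 sits far beyond the scatter and needs much more compound. Compound 4, `COC(=O)C1=C(C)N=C(C)/C(=C(\O)OC)C1c1cc(Cl)cc(Cl)c1`, is not yet measured. Against compound 2 it carries one change: 3,5-dichlorophenyl in place of 2-vinylphenyl on a saturated ring carbon. Among the measured compounds shown here, no measured pair shares this change, so the step is a guess. Compound 3 shows that a change on that phenyl ring can cost a great deal, since it gives 6310 nM. A moderate rise in the number is expected here, smaller than that. Compound 4 is expected to give 30 nM, with a range from 5 nM to 200 nM. This amounts to an expected 6.7-fold higher number from compound 2 to compound 4 (0.83 log units; beyond the scatter).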

Compound 4, half-maximal effective concentration: 93.3 nM
Estimate against measurement, compound 4: 3.1-fold (0.49 log units) below, within the range that was stated.
By their numbers in this assay, from the lowest: compounds 2 and 1 (each within the scatter of the next); then compound 4; then compound 3.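

In this assay, replacing 2-vinylphenyl with 3,5-dichlorophenyl on the saturated ring carbon gives a 21-fold higher number from compound 2 to compound 4 (1.32 log units; beyond the scatter). Both groups have the same count of heavy atoms and one six-membered aromatic ring of carbon only, so at this position the outcome depends on more than the size of the group by that count. The step removes the vinyl group and brings in two chlorines at once, so their shares cannot be separated.

From the compounds shown here alone, how an amine or a carboxylic acid on this phenyl ring would behave remains open. No measurement shown here explains the step.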